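The source may report more compounds than this note shows. Statements on the series, on what has been measured and on what is new or still open speak of the compounds shown alone.

Measured in a functional assay on brain (Rattus norvegicus, strain Wistar) for inhibition; a lower number here means a stronger inhibitor, a higher number a weaker inhibitor:
- Compound 1 `CCCCOc1ccc(-c2c(C)[nH]c(=O)n2C)cc1`: 5100 nM
- Compound 2 `Cc1ccc(-c2c(C)[nH]c(=O)n2C)cc1`: 85300 nM
- Compound 3 `CCCc1ccc(-c2c(C)[nH]c(=O)n2C)cc1`: 21500 nM

The three compounds share one core and differ only in a single group on an aromatic carbon. Compound 3 has the second highest number of the three, so it stands clearly between the other two.

The next compound is compound 4 `Cc1[nH]c(=O)n(C)c1-c1ccc(OC(C)C)cc1`, which carries isopropoxy in place of propyl on an aromatic carbon. Among the compounds with values here, no isopropoxy compound has been measured yet, so the forecast has to lean on its nearest relatives. The butoxy group of compound 1 is the closest measured group. The most relevant measured change is a 4.2-fold higher number from compound 1 to compound 3 (0.62 log units; beyond the scatter), a modest step for propyl in place of butoxy. Two further steps show how much this group matters: a 4.0-fold lower number from compound 2 to compound 3 (0.60 log units; beyond the scatter), also modest, and a 17-fold higher number from compound 1 to compound 2 (1.22 log units; beyond the scatter), which is large. Among these three compounds the number falls in the order methyl, propyl, butoxy, and none goes against that order.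

Isopropoxy should therefore move the number down from that of compound 3, though probably not all the way to that of compound 1. The expected change is a modest one toward a lower number, estimated as a 2.2-fold lower number from compound 3 to compound 4 (0.33 log units; beyond the scatter). For compound 4 the estimated value is 10000 nM, with an expected range from 4500 nM to 22000 nM.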

Compound 4, half-maximal inhibitory concentration: 20400 nM
Compound 4: the middle estimate sits 2.0-fold (0.31 log units) below what was measured; measured number inside the range.
By their numbers in this assay, from the lowest: compound 1; then compounds 4 and 3 (each within the scatter of the next); then compound 2.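

In this assay, exchanging propyl for isopropoxy on this aromatic carbon gives a 1.1-fold lower number from compound 3 to compound 4 (0.02 log units; within the scatter), so these two groups cannot be told apart here, and carrying an oxygen on this carbon is not enough on its own to reach the number of compound 1. Within the data shown here, with that oxygen present in both compounds, the group attached to it still matters: there is a 4.0-fold higher number from compound 1 to compound 4 (0.60 log units; beyond the scatter), the first comparison here in which only the part of the group beyond the oxygen changes. Isopropoxy still improves on the small methyl group, with a 4.2-fold lower number from compound 2 to compound 4 (0.62 log units; beyond the scatter), so among these four compounds methyl gives the highest number and butoxy the lowest, while propyl and isopropoxy sit level in the middle.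

Nothing available here explains why these groups rank as they do. On these data alone, a straight propoxy group would help separate chain length from branching on the oxygen, while a longer chain such as hexyloxy, an amine or a carboxylic acid on this carbon would show how far the trend extends, and all of these remain open.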